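A few compounds are considered here, and "the series" means these few. Any claim that something is new, unique, unknown or untested is made for them only; others in the source may bear on it.

Compound 1 `Cn1nc(-c2ccc(C(F)(F)F)cc2)cc1-c1nnc(S)o1`: > 100000 nM
Compound 2 `Cn1nc(-c2ccc(C(F)(F)F)cc2)cc1-c1nnc(SCc2ccc(C(F)(F)F)cc2)o1`: 27100 nM

In a functional assay on MCF7 cells (Homo sapiens) for cytotoxicity, read by MTT assay, with a stated time of 24 h (on this read-out higher numbers stand for weaker inhibition and lower numbers for stronger inhibition), compound 1 gives > 100000 nM, which is a limit of the assay rather than a number, since it sits at the limit of > 100000 nM in this assay, at which 1 of the 2 values shown sits. Within the data shown here, compound 2 gives 27100 nM, the only actual number among the two values shown. Among the measured compounds shown here, the single measured step is an at least 3.6-fold lower number from compound 1 to compound 2 (0.56 log units; beyond the scatter). Compound 3 `Cn1nc(-c2ccc(C(F)(F)F)cc2)cc1-c1nnc(SCc2cccc([N+](=O)[O-])c2)o1` carries 3-nitrophenyl in place of 4-(trifluoromethyl)phenyl on a saturated chain carbon bound to a sulfur. That measured step exchanged the group on the sulfur, not the substituent on the benzyl ring, so it offers no direct guide here, and no step beyond the scatter is expected: a 1.0-fold lower number from compound 2 to compound 3 (0.00 log units; within the scatter). Compound 3 is therefore estimated at 27000 nM, in the range 9000 nM to 80000 nM.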

Compound 3, half-maximal inhibitory concentration: > 100000 nM
Compound 3 was reported as a limit; the forecaster's own chance of this, stated with the estimate: 15%; at least 3.7-fold (0.56 log units) between middle value and limit.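

The earlier step showed that a benzyl group on the sulfur can bring a measurable number, and this result shows that the group on that benzyl ring matters as well: 3-nitrobenzyl in place of 4-(trifluoromethyl)benzyl gives an at least 3.6-fold higher number from compound 2 to compound 3 (0.56 log units; beyond the scatter) in this assay. So a substituted benzyl on the sulfur is not enough by itself. Compound 3 gives > 100000 nM, which is a limit and not a number, so its step from compound 1 cannot be read: the limit of > 100000 nM in this assay, at which 2 of the 3 values shown sit.

On these data alone, it remains open how a plain benzyl with no ring substituent, or a benzyl carrying an amine, would behave at this position.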